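A few compounds are considered here, and "the series" means these few. Any claim that something is new, unique, unknown or untested is made for them only; others in the source may bear on it.

Compound 1 `CN1CCC2(CC1)CC(S(=O)(=O)c1c(Cl)ccc(NC(=O)Nc3cccc(F)c3Cl)c1O)C2` and compound 2 `CN1CC2(CC(S(=O)(=O)c3c(Cl)ccc(NC(=O)Nc4cccc(F)c4Cl)c3O)C2)C1` share one core and differ only in the amine-bearing group on the sulfonyl sulfur. In an ADME assay on the whole organism (blood, Mus musculus, strain C57BL/6) for pharmacokinetics, read by HPLC, with a stated time of 4 h, at a dose of 2 mg/kg by the intraperitoneal route (a lower number here means less compound in the circulation, a higher number more compound in the circulation at the dose given), compound 1 gives 1390 ng.h/mL, and in this assay compound 2 gives 1050 ng.h/mL. The step of a 1.3-fold lower number from compound 1 to compound 2 (0.12 log units; within the scatter) is small, so the numbers of compound 2 and compound 1 cannot be told apart; of the two values measured, that of compound 2 is simply the one quoted lower, with nothing beyond the scatter separating it from compound 1.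

Compound 3 `C[C@@H]1CN(S(=O)(=O)c2c(Cl)ccc(NC(=O)Nc3cccc(F)c3Cl)c2O)C[C@H](C)O1` again keeps the core and changes only the group on the sulfonyl sulfur: a group of 8 heavy atoms (6 carbon, 1 nitrogen, 1 oxygen; one six-membered non-aromatic ring with 2 hetero atoms) in place of a group of 8 heavy atoms (7 carbon, 1 nitrogen; one four-membered non-aromatic ring of carbon only, one four-membered non-aromatic ring with 1 hetero atom), on a sulfonyl sulfur. Going by the values given here, the one measured step that bears on this position is a 1.3-fold lower number from compound 1 to compound 2 (0.12 log units; within the scatter), which stayed within the scatter, and no measured step shows what an oxygen-containing ring at this place does. On that basis, the step of no change at the digits printed from compound 2 to compound 3 (within the scatter) is expected to stay within the scatter. Compound 3 is therefore estimated at 1050 ng.h/mL, within a range from 400 ng.h/mL to 2800 ng.h/mL.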

Compound 3, area under the concentration-time curve: 279 ng.h/mL
Estimate against measurement, compound 3: 3.8-fold (0.58 log units) above; measured number outside the range, below it.
By their numbers in this assay, from the lowest: compound 3; then compounds 2 and 1 (each within the scatter of the next).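

Compounds 1 and 2 suggested that the group on the sulfonyl sulfur could change without much effect on the circulating level, but the 2,6-dimethylmorpholin-4-yl group shows that this position does respond in this assay. Installing it gives a 3.8-fold lower number from compound 2 to compound 3 (0.58 log units; beyond the scatter) and also a 5.0-fold lower number from compound 1 to compound 3 (0.70 log units; beyond the scatter), so less compound reaches the circulation at the same dose, even though the group that leaves compound 2 and the group that enters have the same count of heavy atoms, and the shared core is untouched. Nothing available here accounts for this drop, so its cause remains unexplained.

The entering group differs from the other two in several ways at once, including its ring oxygen, its methyl groups and its ring shape, so the compounds shown do not reveal which of these features goes with the lower number. A morpholin-4-yl group without the methyl groups, or a piperidin-1-yl group with carbon in place of the ring oxygen, would help to separate these features.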